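The source may hold more compounds than are shown below. What is called first, only, known or untested is meant among the compounds shown, and "the series" means these compounds.

Measured so far in an assay on isolated protein for inhibition of Flap endonuclease 1 (Homo sapiens); a higher number here means a weaker inhibitor, a lower number a stronger inhibitor:
compound 1 `O=C(O)C(=O)CC(=O)c1ccc(Oc2ccccc2)cc1` gives 1750 nM
compound 2 `O=C(O)C(=O)CC(=O)c1ccccc1Cl` gives 3510 nM
compound 3 `O=C(O)C(=O)CC(=O)c1cccc(Cl)c1` gives 6960 nM

Compound 3 stands at the highest of the three numbers in this assay. Its nearest neighbour is compound 2, whose number lies within the scatter of that of compound 3, so no order between the two can be read. Compound 1 is furthest off, with a number that lies beyond the scatter below that of compound 3.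

Compound 4 `O=C(O)C(=O)CC(=O)c1cccc(-c2ccccc2)c1` has not been measured. It differs from compound 3 in one place: phenyl in place of chloro on an aromatic carbon. Going by the values given here, no step between measured compounds matches this change, so the expectation rests on the pair compound 3 and compound 1. A lower number is expected for compound 4 because compound 1, which also carries an aromatic substituent in place of a chloro, gives 1750 nM. The step from compound 3 to compound 4 is expected at about a 2.3-fold lower number from compound 3 to compound 4 (0.37 log units; beyond the scatter), modest and near the edge of the scatter. The estimate for compound 4 is 3000 nM, in the range 1000 nM to 10000 nM.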

Compound 4, half-maximal inhibitory concentration: 3620 nM
Compound 4: the middle estimate sits 1.2-fold (0.08 log units) below what was measured; the range from low to high includes it.
By their numbers in this assay, from the lowest: compounds 1, 2, 4 and 3 (each within the scatter of the next, the first and the last beyond it).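

In this assay, phenyl in place of chloro on the aromatic carbon meta to a group of 8 heavy atoms gives a 1.9-fold lower number from compound 3 to compound 4 (0.28 log units; within the scatter) and so separates the two compounds by no readable amount. At this place, a substituent of 6 heavy atoms with a six-membered aromatic ring of carbon only and a substituent of a single chlorine atom cannot be told apart, so added size alone has not yet shown any readable effect on the number here. Nothing measured on these compounds bears on why the two substituents read alike.

Going by these compounds, whether an amine, a carboxylic acid or a longer alkyl chain at this aromatic carbon would move the number beyond the scatter of compound 3 remains open. Also open, on these data alone, is whether phenyl in place of chloro on any other aromatic carbon of the ring would give a step of similar size.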